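The source may hold more compounds than are shown below. What is called first, only, known or untested is meant among the compounds shown, and "the series" means these compounds.

In a functional assay on SH-SY5Y cells (Homo sapiens) for antagonist activity, read by cAMP accumulation (on this read-out lower numbers stand for lower potency and higher numbers for higher potency (the scale is a negative logarithm)), compound 2 `CCCCOc1ccc(Cc2ccc(NC3=NCCN3)cc2)cc1` gives 9 and compound 1 `CC(C)Oc1ccc(Cc2ccc(NC3=NCCN3)cc2)cc1` gives 8.8, the pair lying close together: a number 0.20 log units higher from compound 1 to compound 2 (within the scatter). Compound 3 `CCCCCCOc1ccc(Cc2ccc(NC3=NCCN3)cc2)cc1` gives 8.2, and the gap to it is clearer: a number 0.80 log units lower from compound 2 to compound 3 (beyond the scatter). Likewise, the measured data show a number 0.60 log units lower from compound 1 to compound 3 (beyond the scatter). Compound 4 `OCCOc1ccc(Cc2ccc(NC3=NCCN3)cc2)cc1` exchanges the butoxy of compound 2 for 2-hydroxyethoxy: hydroxy in place of ethyl on a saturated chain carbon, two bonds along the chain from an oxygen on an aromatic ring. Every measured step swaps one chain for another, and none brings in a hydroxy, so they offer only a rough scale. Compound 3, at 8.2, shows that a change to this chain can cost a modest amount, so a modest drop in this assay is expected. The expected change is a number 1.00 log units lower from compound 2 to compound 4 (beyond the scatter). For compound 4 the estimated value is 8, with an expected range of 7.2 to 8.7.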

Compound 4, negative logarithm of the antagonist equilibrium constant: 8
Beside the measured number, compound 4's estimate shows no gap at the digits printed; low and high end bracket the measured number.
By their numbers in this assay, from the lowest: compounds 4 and 3 (each within the scatter of the next); then compounds 1 and 2 (each within the scatter of the next).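

In this assay, the first chain carrying a hydroxy at this place gives a number 1.00 log units lower from compound 2 to compound 4 (beyond the scatter) and a number 0.80 log units lower from compound 1 to compound 4 (beyond the scatter). Against the long hexyl chain it gives a number 0.20 log units lower from compound 3 to compound 4 (within the scatter), so a 2-hydroxyethoxy group and a hexyloxy group both sit at the low end of this short series. Nothing measured here bears on the reason for these steps. The compounds shown leave open whether the drop follows the hydroxy itself or the shorter chain that carries it. An ethoxy, a 2-methoxyethoxy or a 2-aminoethoxy group at this place would help to tell these apart.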